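This account rests on a few compounds, and the source may have more. Where it says the series, first, only, none or still open, it means among the compounds named here.

For the measured compounds named here, in an ADME assay on MDCKII-LE cells (Canis lupus familiaris) for permeability, in the apical to basolateral direction (on this read-out lower numbers stand for lower permeability and higher numbers for higher permeability), compound 1 `Cc1csc2nc(Cn3cnc4ccccc43)cc(=O)n12` gives 23.4 10^-6 cm/s and compound 2 `Cc1cccn2c(=O)cc(Cn3cnc4ccccc43)nc12` gives 24.2 10^-6 cm/s so these two numbers agree within the usual scatter, and compound 1 stands level with the only other compound measured. Compound 3 `O=c1cc(Cn2cnc3ccccc32)nc2scc(-c3ccccc3)n12` has not been measured yet. It differs from compound 1 in one place, with phenyl in place of methyl on an aromatic carbon. Going by the values given here, no measured pair shows this change, so only a small downward step is expected, estimated as a 1.2-fold lower number from compound 1 to compound 3 (0.07 log units; within the scatter) and within the scatter. Compound 3 is expected at 20 10^-6 cm/s with an estimated range of 9 10^-6 cm/s to 35 10^-6 cm/s once measured.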

Compound 3, apparent permeability: 11.5 10^-6 cm/s
For compound 3 the middle estimate is 1.7-fold (0.24 log units) above the measured one; the range from low to high includes it.
By their numbers in this assay, from the lowest: compound 3; then compounds 1 and 2 (each within the scatter of the next).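

The position on the five-membered ring, on an aromatic carbon next to the ring nitrogen, does respond to the group it carries: in this assay, phenyl in place of methyl gives a 2.0-fold lower number from compound 1 to compound 3 (0.31 log units; beyond the scatter) and this modest step lies beyond the scatter. For the compounds shown here, the earlier compounds offered no step at all, so this is the first sign that a larger aromatic group here can change the number. Nothing measured here gives a reason for the step. Going by these compounds, whether an ethyl group, an amine or a carboxylic acid at this position would lower the number as well stays open. A single change also cannot show whether phenyl would act the same way on the core of compound 2.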